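Aryl group replacement on the ring amine nitrogen

The compounds below may be only part of what the source reports. "The series", "measured", "known", "first", "only" and "open" are said of these compounds alone.

Compound 1 `O=C1c2ccccc2S(=O)(=O)N1CCCCCCN1CCN(c2ccccc2F)CC1` gives 1620 nM in an ADME assay on HEK293 cells for displacement of a labelled ligand from 5-hydroxytryptamine receptor 6 (Homo sapiens), read by radioligand binding, with a stated time of 1 h; a lower number here means a stronger inhibitor, a higher number a weaker inhibitor.
Compound 2 `O=C1c2ccccc2S(=O)(=O)N1CCCCCCN1CCN(c2cccc(Cl)c2Cl)CC1` gives 920 nM in this assay.
Compound 3 `O=C1c2ccccc2S(=O)(=O)N1CCCCCCN1CCN(c2cccc3cccnc23)CC1` gives 1720 nM in this assay.

Compound 3 holds the highest of the three numbers, though all three lie within the scatter of one another: a 1.1-fold higher number from compound 1 to compound 3 (0.03 log units; within the scatter), a 1.9-fold higher number from compound 2 to compound 3 (0.27 log units; within the scatter) and a 1.8-fold lower number from compound 1 to compound 2 (0.25 log units; within the scatter). Compound 4 `O=C1c2ccccc2S(=O)(=O)N1CCCCCCN1CCN(c2ccccn2)CC1` is not yet measured; it differs from compound 3 in one place: pyridin-2-yl in place of quinolin-8-yl on an amine nitrogen in a ring. Every measured step swaps only the aryl group on this ring nitrogen, and none moves this assay beyond the scatter, so a further aryl swap at this place is expected to leave the number close to that of compound 3, with no step beyond the scatter. Compound 4 is therefore estimated at 2000 nM, within 800 nM to 5000 nM, which means an expected step of a 1.2-fold higher number from compound 3 to compound 4 (0.07 log units; within the scatter).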

Compound 4, inhibition constant: 2350 nM
For compound 4 the middle estimate is 1.2-fold (0.07 log units) below the measured one, within the range that was stated.
By their numbers in this assay, from the lowest: compounds 2, 1, 3 and 4 (each within the scatter of the next, the first and the last beyond it).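

In this assay, within the data shown here, pyridin-2-yl gives the only step at this ring nitrogen that lies beyond the scatter (a 2.6-fold higher number from compound 2 to compound 4 (0.41 log units; beyond the scatter)), so the choice of aryl group here can shift the number, if only modestly. Its other two steps stay within the scatter (a 1.4-fold higher number from compound 3 to compound 4 (0.14 log units; within the scatter)) and (a 1.5-fold higher number from compound 1 to compound 4 (0.16 log units; within the scatter)), so compound 4 cannot be separated from compound 3 or compound 1. No measurement at hand gives a cause for these steps.

Open, as far as these compounds go, is whether a benzyl group or a simple alkyl group on this ring nitrogen would keep the number near these values. Also open, from the compounds shown here alone, is how a shorter chain in place of the hexyl linker would read with the 2,3-dichlorophenyl group kept.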